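Cyclopropyl to 4-methoxyphenyl on the sulfur-bound carbon

A few compounds are considered here, and "the series" means these few. Any claim that something is new, unique, unknown or untested is made for them only; others in the source may bear on it.

compound 1 `Cc1cc(Nc2cc(-c3ccccc3)[nH]n2)n2nc(SCc3cccc(Br)c3)nc2n1`: in an ADME assay on GES1 cells (Homo sapiens) for inhibition, read by MTT assay, with a stated time of 72 h (a higher number here means a weaker inhibitor, a lower number a stronger inhibitor), compound 1 reaches only a limit, > 50000 nM.
compound 2 `Cc1cc(Nc2cc(-c3ccccc3)[nH]n2)n2nc(SCCc3ccccc3)nc2n1`: in this assay compound 2 gives 37400 nM.
compound 3 `Cc1cc(Nc2cc(-c3ccccc3)[nH]n2)n2nc(SCC3CC3)nc2n1`: in this assay compound 3 reaches only a limit, > 50000 nM.

Compound 3 therefore has no number of its own in this assay, only a limit, and it shares that limit with compound 1 (the limit of > 50000 nM in this assay, at which 2 of the 3 values shown sit). The step to compound 4 `COc1ccc(CSc2nc3nc(C)cc(Nc4cc(-c5ccccc5)[nH]n4)n3n2)cc1` is 4-methoxyphenyl in place of cyclopropyl on a saturated chain carbon bound to a sulfur. Among the measured compounds shown here, three measured steps concern the same saturated chain carbon bound to a sulfur. Benzyl in place of 3-bromophenyl gives an at least 1.3-fold lower number from compound 1 to compound 2 (0.12 log units; that floor lies within the scatter); cyclopropyl in place of benzyl gives an at least 1.3-fold higher number from compound 2 to compound 3 (0.12 log units; that floor lies within the scatter); cyclopropyl in place of 3-bromophenyl gives a step that the two limits leave unreadable from compound 1 to compound 3. Only compound 2, which carries a benzyl on that carbon, returned a number, and every step among the three compounds is either unreadable or no larger than the scatter. Compound 4 again carries an aromatic ring on that carbon, so it is expected to sit near compound 2, and a step of an at least 1.1-fold lower number from compound 3 to compound 4 (0.04 log units; that floor lies within the scatter) is the most that is expected. Compound 4 is estimated at 45000 nM, within 18000 nM to 110000 nM, with a real chance that the assay returns only a limit once more.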

Compound 4, half-maximal inhibitory concentration: 28200 nM
The estimate for compound 4 lay 1.6-fold (0.20 log units) above the measured number; the range from low to high includes it.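

In this assay compound 4 gives 28200 nM, so a second group on the saturated chain carbon bound to a sulfur now returns a number, and compound 2 no longer stands alone there. The step between these two is a 1.3-fold lower number from compound 2 to compound 4 (0.12 log units; within the scatter), so 4-methoxyphenyl and benzyl cannot be told apart here, while the steps from the other two compounds are only floors, an at least 1.7-fold lower number from compound 3 to compound 4 (0.24 log units; that floor lies within the scatter) and an at least 1.7-fold lower number from compound 1 to compound 4 (0.24 log units; that floor lies within the scatter), and neither floor shows a difference beyond the scatter. Compound 1 and compound 3 remain at a limit and not at a number, and this is why those two steps give no true size: the limit of > 50000 nM in this assay, at which 2 of the 4 values shown sit.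

From the compounds shown here alone, whether any group on this carbon can move the number in this assay beyond the scatter stays open, as does the true distance of compound 1 and compound 3 from the two compounds with numbers. The compounds shown also leave open what an amine or a carboxylic acid in place of the methoxy group, or a longer chain on the sulfur, would do to this reading.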